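The source may report more compounds than this note shows. Statements on the series, on what has been measured and on what is new or still open speak of the compounds shown alone.

Measured compounds:
- compound 1, `COc1cc2oc(-c3cccc(NC(=O)c4ccc(C)cc4)c3)cc(=O)c2c(OC)c1OC`: in a functional assay on UO-31 cells (Homo sapiens) for inhibition, read by sulforhodamine B assay, tested at 10 uM (a higher number here means more inhibition at the concentration tested (going by the name of the read-out), a lower number less inhibition), compound 1 is reported as "active" (no number reported), without a number
- compound 2, `COc1cc2oc(-c3cccc(NC(=O)c4ccc(F)cc4)c3)cc(=O)c2c(OC)c1OC`: in this assay compound 2 is reported as "active" (no number reported), without a number
- compound 3, `COc1cc2oc(-c3cccc(NC(=O)c4ccc(Cl)cc4)c3)cc(=O)c2c(OC)c1OC`: in this assay compound 3 gives 51.1%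

All three share one core and differ only in the ring carried on the amide carbonyl. For the measured compounds named here, compound 3 is the only member of the set with a number attached; for compound 1 the assay reports only "active" (no number reported) and for compound 2 only "active" (no number reported), without a number in either case, so nothing can be said about how they compare with compound 3 or with each other, and no step between measured compounds can be drawn.

The next compound, compound 4, `COc1cc2oc(-c3cccc(NC(=O)c4cccc(Br)c4)c3)cc(=O)c2c(OC)c1OC`, is made from compound 3 by a single change, (3-bromophenyl in place of 4-chlorophenyl on a carbonyl carbon). The halogen changes from chlorine to bromine and moves from the 4-position to the 3-position of the phenyl ring. Going by the values given here, with no measured step to lean on, the expected move from compound 3 to compound 4 in this assay, a number 1.1 percentage points lower from compound 3 to compound 4 (within the scatter), is small and within the usual scatter, in no particular direction. Compound 4 is therefore estimated at about 50%, with a range from 30% to 70%.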

Compound 4, a percentage reported as inhibition, at one concentration (the size of the read-out at that concentration, not a potency): "active" (no number reported)
Compound 4 has no reported number here; there is nothing to compare the estimate with.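

For the compounds shown here, compound 4 is reported in this assay only as "active" (no number reported), so no step from compound 3 to compound 4 can be read, and no evidence bears on this result. The compounds shown leave open how much inhibition compound 1, compound 2 and compound 4 give compared with compound 3.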